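The source may hold more compounds than are shown below. What is called first, only, known or untested is meant among the compounds shown, and "the series" means these compounds.

Of the compounds shown here, three of a shared core have been measured in a functional assay on HCT-116 cells (Homo sapiens) for antiproliferative activity, read by CCK-8 assay, with a stated time of 72 h, tested at 2 uM; a lower number here means a weaker effect, a higher number a stronger effect of the compound at the concentration tested. Compound 1 `Nc1ccccc1NC(=O)/C=C/c1ccc(Cn2cnc3c(Nc4cccc(Cl)c4)nc(Cl)nc32)cc1` gives 12.9% in this assay. Compound 2 `Nc1ccccc1NC(=O)/C=C/c1ccc(Cn2cnc3c(Nc4ccccc4)nc(Cl)nc32)cc1` gives 7.75%, and a number 5.2 percentage points lower from compound 1 to compound 2 (within the scatter). Among the compounds with values here, compound 3 `Nc1ccccc1NC(=O)c1ccc(Cn2cnc3c(Nc4ccccc4)nc(Cl)nc32)cc1` gives 71.4%, which is the highest of the three numbers, and a number 63.7 percentage points higher from compound 2 to compound 3 (beyond the scatter); this is the one step that stands out clearly.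

Compound 4 `Nc1ccccc1NC(=O)c1ccc(Cn2cnc3c(Nc4cccc(OC(F)(F)F)c4)nc(Cl)nc32)cc1` has not yet been measured in this assay. The change from compound 3 to compound 4 is trifluoromethoxy in place of hydrogen on an aromatic carbon. Within the data shown here, the nearest guide among the measured steps is the one from compound 1 to compound 2, which removes a chloro at the same place, meta to a large group, while the rest of the molecule stays fixed: that step was within the scatter. Among the measured compounds shown here, no measured step involves a trifluoromethoxy group, so its effect at this place is unknown, and the one comparable substitution suggests a small effect at most.

Compound 4 is therefore expected to sit close to compound 3, with a number 3.4 percentage points lower from compound 3 to compound 4 (within the scatter) lying within the scatter. The estimate for compound 4 in this assay is 68%, with a plausible range from 45% to 88%.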

Compound 4, a percentage reported as inhibition, at one concentration (the size of the read-out at that concentration, not a potency): 1.6%
Beside the measured number, compound 4's estimate is 66.4 percentage points above it; the whole stated range lies above it.
By their numbers in this assay, from the lowest: compounds 4, 2 and 1 (each within the scatter of the next, the first and the last beyond it); then compound 3.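

In this assay, trifluoromethoxy on the anilino ring, on an aromatic carbon meta to a large group, goes with a number 69.8 percentage points lower from compound 3 to compound 4 (beyond the scatter), which shows that this position is far from indifferent to what it carries when the core bears the (2-aminophenyl)carbamoyl group. Within the data shown here, the only earlier change at this place, a number 5.2 percentage points lower from compound 1 to compound 2 (within the scatter), lay within the scatter, but both of those compounds carry the 2-((2-aminophenyl)carbamoyl)ethenyl group and already sit at the low end of the read-out, so that step could say little about how the same place behaves in compound 3. No measurement available here accounts for the size of the new step.

The compounds shown leave open whether the drop belongs to trifluoromethoxy itself or would follow any group on this carbon; a fluoro, a methyl, a methoxy or an amine there, on the core of compound 3, would begin to separate those readings. Also open, on these data alone, is whether trifluoromethoxy at another carbon of the same ring would give a similar result, since a single position has been sampled with this group.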